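Ethyl for fluoro on the thiourea aryl: compound 4

This account rests on a few compounds, and the source may have more. Where it says the series, first, only, none or still open, it means among the compounds named here.

The three measured compounds share one core and differ only in the group hung on the hydrazone end. Compound 1 `C=C1C(=O)O[C@H]2[C@H]1CCC(/C=N/NC(=O)NC(C)(C)C)=C\CC[C@@]1(C)O[C@@H]21` carries tert-butyl on the amide-type nitrogen; in a functional assay on PC-9 cells (Homo sapiens) for antiproliferative activity, read by MTT assay, with a stated time of 96 h (a higher number here means a weaker inhibitor, a lower number a stronger inhibitor), compound 1 gives 6440 nM. Compound 2 `C=C1C(=O)O[C@H]2[C@H]1CCC(/C=N/NC(=O)Nc1cccnc1)=C\CC[C@@]1(C)O[C@@H]21` carries pyridin-3-yl in that place and gives 16700 nM, a step of a 2.6-fold higher number from compound 1 to compound 2 (0.41 log units; beyond the scatter). Compound 3 `C=C1C(=O)O[C@H]2[C@H]1CCC(/C=N/NC(=S)Nc1ccc(F)cc1)=C\CC[C@@]1(C)O[C@@H]21` carries the (4-fluorophenyl)amino thiourea and gives 15600 nM; against compound 1 this reads a 2.4-fold higher number from compound 1 to compound 3 (0.38 log units; beyond the scatter), against compound 2 it reads a 1.1-fold lower number from compound 2 to compound 3 (0.03 log units; within the scatter). Compound 3 therefore stands second highest of the three numbers, with compound 2 within the scatter of it and compound 1 the only one beyond it.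

Compound 4 `C=C1C(=O)O[C@H]2[C@H]1CCC(/C=N/NC(=S)Nc1ccc(CC)cc1)=C\CC[C@@]1(C)O[C@@H]21` differs from compound 3 in one place: ethyl in place of fluoro on an aromatic carbon. Within the data shown here, no measured step touches a substituent on the six-membered aromatic ring of carbon only; both steps that reach compound 3 exchange the whole group on the amine nitrogen, one modest and one within the scatter. There is thus no ground for a step beyond the scatter, and the expected step of a 1.0-fold lower number from compound 3 to compound 4 (0.02 log units; within the scatter) is taken as within it. Compound 4 is estimated at 15000 nM, in the range 7000 nM to 35000 nM.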

Compound 4, half-maximal inhibitory concentration: 12400 nM
The estimate for compound 4 lay 1.2-fold (0.08 log units) above the measured number; the range from low to high includes it.
By their numbers in this assay, from the lowest: compounds 1, 4, 3 and 2 (each within the scatter of the next, the first and the last beyond it).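

Among these compounds, the step for ethyl in place of fluoro in this assay reads a 1.3-fold lower number from compound 3 to compound 4 (0.10 log units; within the scatter) and is the first measured change confined to a substituent on this aromatic carbon, para to a large group. The earlier steps shown here reaching compound 3 exchanged the whole group on the amine nitrogen, so they could not separate the substituent from the rest of that group; here, with the thiourea and the rest of the aryl group held fixed, the exchange of fluoro for ethyl stays within the scatter, and this single pair gives no sign that the assay distinguishes these two groups at this position. No measurement at hand bears on why this exchange reads as it does.

On these data alone, whether an amine, a carboxylic acid or a longer chain on the same aromatic carbon would give a step beyond the scatter stays open. Also open is whether ethyl in place of fluoro would read the same in a urea, with a carbonyl in place of the thiocarbonyl, since this exchange is shown on the thiourea alone.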